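The source may hold more compounds than are shown below. What is called first, only, known or untested is meant among the compounds shown, and "the series" means these compounds.

Working notes on the series. In a physicochemical assay for solubility, read by HPLC, in phosphate buffer, at pH 6.5 (on this read-out lower numbers stand for lower solubility and higher numbers for higher solubility), compound 1 (`COC(=O)C1=C(C)NC(c2nccs2)=NC1(C)c1ccc(F)cc1Cl`) gives 18 ug/mL and compound 2 (`COC(=O)C1=C(CN2CCNC(=O)C2)NC(c2nccs2)=NC1(C)c1ccc(F)cc1`) gives 34 ug/mL. These two numbers lie within the scatter of each other, so the data so far do not separate compound 2 from compound 1. The pair also differs in more than one place, so no single-change step can be read from it.

Compound 3 (`COC(=O)C1=C(CN(C)C2(C(=O)O)CC2)NC(c2nccs2)=NC1(C)c1ccc(F)cc1`) is still to be measured in this assay. Its change from compound 2 is a group of 8 heavy atoms (5 carbon, 1 nitrogen, 2 oxygen; one three-membered non-aromatic ring of carbon only) in place of a group of 7 heavy atoms (4 carbon, 2 nitrogen, 1 oxygen; one six-membered non-aromatic ring with 2 hetero atoms), on a saturated chain carbon bound to a double-bonded ring carbon. The 3-oxopiperazin-1-yl group goes, and the group that enters has one three-membered non-aromatic ring of carbon only. Within the data shown here, no measured step shows what such an exchange does, so the expectation is a judgement from the structures alone and carries a wide range. A rise beyond the scatter is expected, rather than no change. The estimated step is an 8.8-fold higher number from compound 2 to compound 3 (0.95 log units; beyond the scatter). For compound 3 the estimated value is 300 ug/mL, with an expected range of 60 ug/mL to 1200 ug/mL.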

Compound 3, solubility: > 510 ug/mL
Compound 3 was reported as a limit (the forecaster's own chance of this, stated with the estimate: 15%); middle value at least 1.7-fold (0.23 log units) from the limit.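

On the saturated chain carbon bound to a double-bonded ring carbon, the series now has its first step that can be read as a single change: in this assay, putting the new group with its three-membered non-aromatic ring of carbon only in place of 3-oxopiperazin-1-yl gives an at least 15-fold higher number from compound 2 to compound 3 (1.17 log units; beyond the scatter) and so lies beyond the scatter. Compounds 1 and 2 could not show this, since their values lie within the scatter of each other and they differ in more than one place; this one place alone can now be seen to carry a large step on the read-out, with the rest of the structure held constant. The result for compound 3 is a limit of the assay and not a number: the limit of > 510 ug/mL in this assay, at which 1 of the 3 values shown sits.

On these data alone, the true size of the step therefore stays unknown, and a single step cannot show which part of the entering group goes with it, whether the three-membered ring, the carboxylic acid or the methyl-bearing nitrogen. As far as these compounds go, whether a morpholine or a plain dimethylamino group on the same carbon would give a step of like size also stays open.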